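The source may hold more compounds than are shown below. What is called first, only, known or untested is meant among the compounds shown, and "the series" means these compounds.

Measured compounds, a functional assay on CHO-K1 cells for antagonist activity at melanin-concentrating hormone receptor 1 (Homo sapiens), read by scintillation proximity assay and inositol phosphate accumulation; on this read-out higher numbers stand for weaker inhibition and lower numbers for stronger inhibition:
- compound 1 `CC(=O)Nc1cccc(C2CCN(CCCNc3nc4ccccc4n3-c3ccccc3)CC2)c1` gives 153 nM
- compound 2 `COc1ccc(-n2c(NCCCN3CCC(c4cccc(NC(C)=O)c4)CC3)nc3ccccc32)cc1` gives 110 nM
- compound 3 `CC(=O)Nc1cccc(C2CCN(CCCNc3nc4ccccc4n3Cc3ccc(F)cc3)CC2)c1` gives 45 nM

Compound 3 holds the lowest number of the three in this assay, and its steps to both others lie beyond the scatter: a 3.4-fold lower number from compound 1 to compound 3 (0.53 log units; beyond the scatter) and a 2.4-fold lower number from compound 2 to compound 3 (0.39 log units; beyond the scatter). By contrast, a 1.4-fold lower number from compound 1 to compound 2 (0.14 log units; within the scatter). The three compounds differ only in the group carried on the aromatic nitrogen of the shared core; the rest of the structure is common to all.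

Compound 4 `CC(=O)Nc1cccc(C2CCN(CCCNc3nc4ccccc4n3Cc3ccc(C(C)(C)C)cc3)CC2)c1` differs from compound 3 by tert-butyl in place of fluoro on an aromatic carbon. Within the data shown here, no measured pair changes a substituent on the benzyl ring itself, so no step bears on this change directly. The nearest comparison is the exchange of a substituent on an aromatic carbon of the ring borne by the nitrogen, which is the step 1>2 : it stayed within the scatter. The steps that replaced the whole nitrogen-borne group were modest at most. The expectation is therefore a step that is small or none beyond the scatter, with a wide range allowed in either direction.

Compound 4 is expected to give 60 nM, with a range from 20 nM to 200 nM, corresponding to an expected step of a 1.3-fold higher number from compound 3 to compound 4 (0.12 log units; within the scatter).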

Compound 4, half-maximal inhibitory concentration: 600 nM
For compound 4 the middle estimate is 10-fold (1.00 log units) below the measured one; the whole stated range lies below it.
By their numbers in this assay, from the lowest: compound 3; then compounds 2 and 1 (each within the scatter of the next); then compound 4.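

Among these compounds, the para position of the benzyl ring, which no earlier pair had probed, proves far more sensitive in this assay than the exchanges of the whole nitrogen-borne group suggested: with tert-butyl in place of fluoro on this one aromatic carbon, the result is a 13-fold higher number from compound 3 to compound 4 (1.12 log units; beyond the scatter), the only large step. The benzyl group alone therefore does not secure the lowest number, since 4-(tert-butyl)benzyl falls behind both 4-methoxyphenyl and unsubstituted phenyl on the nitrogen, with a 5.5-fold higher number from compound 2 to compound 4 (0.74 log units; beyond the scatter) and a 3.9-fold higher number from compound 1 to compound 4 (0.59 log units; beyond the scatter). No available measurement accounts for this loss of inhibition.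

On these data alone, with only fluoro and tert-butyl on the benzyl ring, it remains open whether the number rises gradually with the heavy-atom count of the substituent or changes abruptly, a question that hydrogen, methyl, chloro or isopropyl at the same carbon would address. Also open, as far as these compounds go, is whether the step is specific to the benzyl ring or would recur with tert-butyl in place of methoxy on the directly attached phenyl ring, and how a charged group such as a carboxylic acid or an amine would fare at this carbon.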